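This account rests on a few compounds, and the source may have more. Where it says the series, first, only, none or still open, it means among the compounds named here.

In a physicochemical assay, read by spectrophotometry, with a stated time of 6 min (on this read-out higher numbers stand for weaker inhibition and lower numbers for stronger inhibition), compound 1 (`O=C(CCc1nc2ccccc2c(=O)[nH]1)N/N=C/c1ccc(O)cc1`) gives 105000000 nM and compound 2 (`COc1cc(/C=N/NC(=O)CCc2nc3ccccc3c(=O)[nH]2)cc(OC)c1O`) gives 105000000 nM in the same measurement, so the two stand level, within the usual scatter. Compound 3 (`COc1ccc(/C=N/NC(=O)CCc2nc3ccccc3c(=O)[nH]2)cc1`) keeps the core of compound 1 with one change (methyl in place of hydrogen on an oxygen on an aromatic ring): methyl in place of hydrogen on an oxygen on an aromatic ring, so that hydroxy becomes methoxy and 4-hydroxyphenyl becomes 4-methoxyphenyl.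

Among the compounds with values here, no pair of measured compounds shows this change, so its size can only be estimated. In this assay no step beyond the scatter is expected, although any drift seems more likely to go towards higher numbers, meaning weaker inhibition. Compound 3 would lack the free hydroxy that compound 1 carries, and compound 2 at 105000000 nM has a free hydroxy as well, so the expected range is left wider on the high side. The estimated step (a 1.2-fold higher number from compound 1 to compound 3 (0.08 log units; within the scatter)) is expected to stay within the scatter. For compound 3 the estimated value is 125000000 nM with 70000000 nM and 300000000 nM as the expected ends of the range.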

Compound 3, half-maximal inhibitory concentration: 75000000 nM
The estimate for compound 3 lay 1.7-fold (0.22 log units) above the measured number; low and high end bracket the measured number.
By their numbers in this assay, from the lowest: compounds 3, 1 and 2 (each within the scatter of the next).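

In this assay, putting a methyl in place of the hydrogen on the oxygen on the aromatic ring, so that 4-hydroxyphenyl becomes 4-methoxyphenyl, gives a 1.4-fold lower number from compound 1 to compound 3 (0.15 log units; within the scatter) and the two compounds therefore stand level. Within the data shown here, this is the first reading at this position, and it shows that in this measurement the free hydroxy of compound 1 can be replaced by methoxy without a step beyond the scatter, so compound 3 needs no free hydroxy to stay level with compound 1. No supporting measurement is available to explain why the number holds when this hydrogen is replaced.

The compounds shown leave open whether a larger group on the same oxygen, such as ethoxy or a longer chain, would also stay level with compound 1, or whether only the small methyl does so. They also leave open whether an amine or a carboxylic acid in place of the hydroxy would produce a step beyond the scatter, which would show that this position can influence the read-out at all.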